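The source may report more compounds than this note shows. Statements on the series, on what has been measured and on what is new or still open speak of the compounds shown alone.

Working notes on the series.

Three compounds share one core and differ only in the substituent on the cinnamoyl ring. Compound 1 `Cc1ccc(/C=C/C(=O)Nc2nnc(-c3ccc(Cl)cc3)s2)cc1` in a functional assay on A549 cells (Homo sapiens) for antiproliferative activity, read by MTT assay, with a stated time of 48 h (on this read-out lower numbers stand for stronger inhibition and higher numbers for weaker inhibition), gives 1.25 ug/mL. Compound 2 `COc1ccc(/C=C/C(=O)Nc2nnc(-c3ccc(Cl)cc3)s2)cc1` in this assay gives 1.38 ug/mL. Compound 3 `O=C(/C=C/c1ccc(F)cc1)Nc1nnc(-c2ccc(Cl)cc2)s1` in this assay gives 2.06 ug/mL. Going by the values given here, the steps of a 1.1-fold higher number from compound 1 to compound 2 (0.04 log units; within the scatter), a 1.6-fold higher number from compound 1 to compound 3 (0.22 log units; within the scatter) and a 1.5-fold higher number from compound 2 to compound 3 (0.17 log units; within the scatter) are all within the scatter, so the three compounds cannot be separated on these numbers; compound 3 is merely the one whose number sits at the top of a narrow band.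

Compound 4 `COc1ccc(-c2nnc(NC(=O)/C=C/c3ccc(F)cc3)s2)cc1` differs from compound 3 in methoxy in place of chloro on an aromatic carbon, the methoxy entering para to a large group on the other aryl ring, the one attached directly to the core. Among the compounds with values here, no measured step touches that ring; the measured steps all exchange substituents on the cinnamoyl ring, and each stayed within the scatter, the largest being a 1.6-fold higher number from compound 1 to compound 3 (0.22 log units; within the scatter). Within the data shown here, there is thus no direct precedent for this change, and the only guidance is that the series has so far been flat. The expected step of a 1.0-fold lower number from compound 3 to compound 4 (0.01 log units; within the scatter) is therefore none beyond the scatter, in no preferred direction. Compound 4 is estimated at 2 ug/mL in this assay, with a range from 0.9 ug/mL to 4.5 ug/mL, widened for the lack of a direct precedent.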

Compound 4, half-maximal inhibitory concentration: 0.75 ug/mL
Compound 4: middle estimate off by 2.7-fold (0.43 log units), on the high side; the measured number lies below the stated range.
By their numbers in this assay, from the lowest: compounds 4, 1, 2 and 3 (each within the scatter of the next, the first and the last beyond it).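

Going by these compounds alone, exchanging 4-chlorophenyl for 4-methoxyphenyl gives a 2.7-fold lower number from compound 3 to compound 4 (0.44 log units; beyond the scatter) in this assay and is the first step to lie beyond the scatter, although it remains modest in size. Within the data shown here, the earlier steps all exchanged substituents on the cinnamoyl ring and all stayed within the scatter, so the flat picture drawn from them does not extend to the ring that carries the chloro or the methoxy, which is the first place where a single change separates two compounds. This reading rests on one pair with fluoro on the cinnamoyl ring, and no measurement on hand accounts for the step.

Still open, on these data alone, is whether the same exchange holds with methyl or methoxy on the cinnamoyl ring, which would show whether the two rings contribute independently or the step belongs to the fluoro compound alone. Also open, as far as these compounds go, is how far the position tolerates other groups, and an ethoxy, a hydroxyl or a dimethylamino group in the place of the methoxy would show whether the step is specific to methoxy or extends to other replacements for chloro.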